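From pyridin-3-yl to 5-aminopyridin-3-yl on compound 1

The source may hold more compounds than are shown below. What is called first, only, known or untested is meant among the compounds shown, and "the series" means these compounds.

In a functional assay on A2780 cells (Homo sapiens) for antiproliferative activity, read by CellTiter-Glo, with a stated time of 72 h (a higher number here means a weaker inhibitor, a lower number a stronger inhibitor), compound 1 (`C[C@H](NC(=O)C1CCOCC1)c1ccc(NC(=O)N2CC(c3cccnc3)C2)cc1`) gives 17 nM and compound 2 (`C[C@H](NC(=O)[C@@H]1CCCN1C)c1ccc(NC(=O)N2CC(c3cccnc3)C2)cc1`) gives 5.7 nM, so compound 1 holds the higher of the two numbers. Compound 3 (`C[C@H](NC(=O)C1CCOCC1)c1ccc(NC(=O)N2CC(c3cncc(N)c3)C2)cc1`) keeps the core of compound 1 and differs by one change, (amino in place of hydrogen on an aromatic carbon), which turns pyridin-3-yl into 5-aminopyridin-3-yl. Among the measured compounds shown here, the only measured step is a 3.0-fold lower number from compound 1 to compound 2 (0.47 log units; beyond the scatter). That modest step, beyond the scatter, concerns the group on a carbonyl carbon and leaves the pyridin-3-yl untouched. For the measured compounds named here, no measured compound carries a change on this ring, so the data give no firm direction and serve only as a gauge of size. A small step is expected, leaning towards a weaker number: the estimate is a 1.4-fold higher number from compound 1 to compound 3 (0.15 log units; within the scatter). Compound 3 is expected at 24 nM, with an estimated range of 7 nM to 80 nM.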

Compound 3, half-maximal inhibitory concentration: 500 nM
Compound 3: middle estimate off by 21-fold (1.32 log units), on the low side; the measured number lies above the stated range.
By their numbers in this assay, from the lowest: compound 2; then compound 1; then compound 3.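

In this assay the first change shown on this ring gives a 29-fold higher number from compound 1 to compound 3 (1.47 log units; beyond the scatter) and so marks the pyridin-3-yl as a sensitive part of compound 1. A single amino on the aromatic carbon two atoms from the ring nitrogen moves the number further than the change on the carbonyl carbon does in a 3.0-fold lower number from compound 1 to compound 2 (0.47 log units; beyond the scatter) and in the opposite direction. No measurement given here accounts for this loss.

On these data alone, it remains open whether the loss belongs to the amino itself or would follow any group on this carbon, such as a methyl, a fluorine or a methoxy. As far as these compounds go, it is also open whether 5-aminopyridin-3-yl would cost as much with the 1-methylpyrrolidin-2-yl of compound 2 on the carbonyl carbon.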